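A few compounds are considered here, and "the series" means these few. Any claim that something is new, unique, unknown or untested is made for them only; others in the source may bear on it.

Of the compounds shown here, two have been measured in a functional assay on ACHN cells (Homo sapiens) for cytotoxicity, read by sulforhodamine B assay, tested at 10 uM; a higher number here means more inhibition at the concentration tested (going by the name of the read-out), a lower number less inhibition. Compound 1 `CC(=O)OC[C@H]1O[C@@H](n2cc(-c3cc(-c4ccccc4)no3)c(=O)[nH]c2=O)C[C@@H]1OC(C)=O` gives 97.6% in this assay. Compound 2 `CC(=O)OC[C@H]1O[C@@H](n2cc(-c3cn(Cc4ccccc4)nn3)c(=O)[nH]c2=O)C[C@@H]1OC(C)=O` gives 99% in this assay. The gap between compound 1 and compound 2 lies within the scatter, so the two stand together near the top of the scale with nothing to separate them. Among the measured compounds shown here, no step between two measured compounds that differ in one place is available, so the effect of any single change on this read-out is not yet known from the series itself.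

Compound 3 `CC(=O)OC[C@H]1O[C@@H](n2cc(-c3cc(-c4ccc(C(C)C)cc4)no3)c(=O)[nH]c2=O)C[C@@H]1OC(C)=O` has not been measured. It differs from compound 1 in one place: isopropyl in place of hydrogen on an aromatic carbon. For the measured compounds named here, the measured compounds give no step that would show what an added isopropyl does here, so the expectation rests on the level of compound 1 alone. Because compound 1 already gives 97.6% in this assay and the read-out has little room to rise, the expected step is a number 3.6 percentage points lower from compound 1 to compound 3 (within the scatter), within the scatter or a slight fall. For compound 3 the value in this assay is estimated at 94%, with a range from 75% to 100%.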

Compound 3, a percentage reported as inhibition, at one concentration (the size of the read-out at that concentration, not a potency): 90.1%
Compound 3: the middle estimate sits 3.9 percentage points above what was measured, and the stated range covers the measured number.
By their numbers in this assay, from the lowest: compounds 3, 1 and 2 (each within the scatter of the next).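

The series now holds its first step between two compounds that differ in one place: in this assay, isopropyl in place of hydrogen on an aromatic carbon, para to a large group, gives a number 7.5 percentage points lower from compound 1 to compound 3 (within the scatter) and so does not separate the pair. This position on the phenyl therefore accepts a branched group of 3 heavy atoms without the read-out leaving the upper part of its scale, with compound 3 at 90.1% in this assay and no change that can be told from the scatter. No independent measurement bears on this step, and nothing here explains it.

As far as these compounds go, with all values this close to the top of the scale and read at a single concentration, a smaller effect of isopropyl on cytotoxicity cannot be resolved, and the same change on compound 2 remains open. From the compounds shown here alone, whether an amine, a carboxylic acid or a longer alkyl chain at the same place on the phenyl would bring the read-out down beyond the scatter also remains open.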